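The compounds below may be only part of what the source reports. "The series", "measured", "known", "first", "only" and "open" are said of these compounds alone.

Measured in a functional assay on K562 cells (Homo sapiens) for inhibition, read by trypan blue exclusion, with a stated time of 48 h (a lower number here means a stronger inhibitor, a higher number a weaker inhibitor), read as half-maximal inhibitory concentration:

- compound 1 `NC(=O)c1cc(Br)ccc1NC(=O)/C=C/c1ccccc1Cl`: 8100 nM
- compound 2 `NC(=O)c1cc(Br)ccc1NC(=O)/C=C/c1ccccc1Br`: > 10000 nM (a limit)
- compound 3 `NC(=O)c1cc(Br)ccc1NC(=O)/C=C/c1cccc(Br)c1`: > 10000 nM (a limit)

Compound 3 has no number, only a limit. Compound 3 sits at the limit of > 10000 nM in this assay, at which 2 of the 3 values shown sit.

Compound 4 `Cc1cccc(/C=C/C(=O)Nc2ccc(Br)cc2C(N)=O)c1` has methyl in place of bromo on an aromatic carbon, meta to a large group: methyl in place of bromo on an aromatic carbon. The same difference reads 3-bromophenyl to 3-methylphenyl.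

For the measured compounds named here, no measured step makes this exchange. The nearest evidence is an at least 1.2-fold higher number from compound 1 to compound 2 (0.09 log units; that floor lies within the scatter) and an at least 1.2-fold higher number from compound 1 to compound 3 (0.09 log units; that floor lies within the scatter), and both of these floors lie within the scatter. The third step is a step that the two limits leave unreadable from compound 2 to compound 3, which gives no size.

With no readable step to draw on, no step beyond the scatter is expected in this assay, and no direction is favoured. The expected step is a number no higher from compound 3 to compound 4 (the limit leaves the size open). Compound 4 may also be reported only as a limit. For compound 4 the estimated value is 10000 nM, with an expected range of 4000 nM to 25000 nM.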

Compound 4, half-maximal inhibitory concentration: > 10000 nM
Compound 4: only a limit was reported; the forecaster's own chance of this, stated with the estimate: 65%; the middle value sits exactly at the limit.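

In this assay, methyl in place of bromo on an aromatic carbon, meta to a large group, gives compound 4 only a limit, > 10000 nM. For the compounds shown here, with bromo or methyl at this position, the result stays at the same limit: the limit of > 10000 nM in this assay, at which 3 of the 4 values shown sit. The steps from compound 3 to compound 4 and from compound 2 to compound 4 cannot be read, and the only readable step is an at least 1.2-fold higher number from compound 1 to compound 4 (0.09 log units; that floor lies within the scatter).

Going by these compounds alone, compound 1, carrying 2-chlorophenyl, remains the only compound here with a number, so the series gives no measured size for any change at this position. As far as these compounds go, whether an amine or a carboxylic acid on this aromatic carbon would give a number in this assay stays open.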